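Replacing a 4-chlorophenyl with a pentafluorophenyl

The compounds below may be only part of what the source reports. "The series", "measured", "known", "first", "only" and "open" are said of these compounds alone.

Compound 1 `Cc1cc(=O)c2c(O)c(CN3CCCC3)c(O)c([C@H]3CCN(C)C[C@H]3O)c2o1` (28%)
Compound 2 `Cc1oc2c([C@H]3CCN(C)C[C@H]3O)c(O)cc(O)c2c(=O)c1C(O)c1csc([N+](=O)[O-])c1` (41%)
Compound 3 `CN1CC[C@H](c2c(O)cc(O)c3c(=O)cc(/C=C/c4ccc(Cl)cc4)oc23)[C@H](O)C1` (88%)

All three values come from a functional assay on MIA PaCa-2 cells (Homo sapiens) for inhibition, read by MTT assay, with a stated time of 48 h, tested at 10 uM (a higher number here means more inhibition of growth at the concentration tested, a lower number less inhibition of growth), and among them compound 3 stands highest (88%). Both compound 2 (41%) and compound 1 (28%) lie lower by more than the usual scatter. These compounds differ from one another in more than one place, so their gaps do not show what any single change does.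

Compound 4 `CN1CC[C@H](c2c(O)cc(O)c3c(=O)cc(/C=C/c4c(F)c(F)c(F)c(F)c4F)oc23)[C@H](O)C1` is still unmeasured. It departs from compound 3 in one place only: 2,3,4,5,6-pentafluorophenyl in place of 4-chlorophenyl on a double-bonded chain carbon bound to a double-bonded chain carbon with 2,3,4,5,6-pentafluorophenyl in place of 4-chlorophenyl on a double-bonded chain carbon bound to a double-bonded chain carbon. The aromatic ring stays a six-membered ring of carbon only and the rest of the structure is unchanged. Going by the values given here, no measured pair tests this swap, so any forecast is loose. With compound 3 already at a high value (88%) there is little room upward, and a modest fall in this assay is expected, quite possibly none beyond the scatter. The expected change is a number 10 percentage points lower from compound 3 to compound 4 (within the scatter) as estimated here. For compound 4 the estimated value is 78% (expected range 58% to 93%).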

Compound 4, percent growth inhibition at one concentration: 89%
The estimate for compound 4 lay 11 percentage points below the measured number; measured number inside the range.
By their numbers in this assay, from the lowest: compound 1; then compound 2; then compounds 3 and 4 (each within the scatter of the next).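

In this assay, going by these compounds alone, placing 2,3,4,5,6-pentafluorophenyl in place of 4-chlorophenyl on a double-bonded chain carbon bound to a double-bonded chain carbon gives a number 1 percentage points higher from compound 3 to compound 4 (within the scatter), the only comparison in this set that isolates a single change. It shows that, at this position and in this assay, exchanging the chlorine-bearing ring for the fluorine-bearing ring leaves growth inhibition within the scatter, so activity here does not depend on the 4-chlorophenyl group specifically. Nothing at hand explains why the two rings read alike, as no measurement bears on the cause.

This read-out uses a single concentration, and compound 3 and compound 4 both stand high on it. Any difference in potency between them could remain hidden, and a full concentration series would be needed to settle this. The compounds shown also leave open whether this position would accept a pyridine ring, a cyclohexyl ring or a phenyl ring carrying a carboxylic acid or an amine, and compound 1 and compound 2 differ from these compounds in too many places to answer that.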